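A few compounds are considered here, and "the series" means these few. Any claim that something is new, unique, unknown or untested is made for them only; others in the source may bear on it.

Compounds measured so far:
compound 1 `COc1cc(-c2nn(-c3cccc(NC(=O)Nc4ccc(Cl)c(Cl)c4)c3)cc2-c2ccncc2)ccc1Cl`: 390 nM
compound 2 `O=C(Nc1cccc(-n2cc(-c3ccncc3)c(-c3ccc(Cl)c(O)c3)n2)c1)Nc1ccc(Cl)c(Cl)c1`: 1030 nM
compound 3 `O=C(Nc1cccc(-n2cc(-c3ccncc3)c(-c3ccc(Cl)c(O)c3)n2)c1)Nc1cc(C(F)(F)F)cc(C(F)(F)F)c1`: 480 nM

In a functional assay on RPMI-8226 cells (Homo sapiens) for inhibition, read by sulforhodamine B assay, with a stated time of 48 h (a lower number here means a stronger inhibitor, a higher number a weaker inhibitor), compound 1 gives 390 nM, the lowest of the three numbers; compound 3 gives 480 nM, within the scatter of it, while compound 2 gives 1030 nM. Among the measured compounds shown here, the only single-point step measured, a 2.6-fold higher number from compound 1 to compound 2 (0.42 log units; beyond the scatter), concerns a different part of the molecule. Compound 4 `COc1cc(-c2nn(-c3cccc(NC(=O)Nc4ccc(Cl)c(C(F)(F)F)c4)c3)cc2-c2ccncc2)ccc1Cl` differs from compound 1 by trifluoromethyl in place of chloro on an aromatic carbon. For the measured compounds named here, no measured step touches this position directly. Compounds 2 and 3 carry different substituents on the same outer ring. Compound 2 gives 1030 nM. Compound 3 gives 480 nM. These two values show that a change there can move the number somewhat. With no closer guide, the expectation for compound 4 is a number close to that of compound 1, with a 1.1-fold lower number from compound 1 to compound 4 (0.05 log units; within the scatter) expected to stay within the scatter. Compound 4 is therefore estimated at 350 nM, expected to fall between 150 nM and 800 nM.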

Compound 4, half-maximal inhibitory concentration: 870 nM
Compound 4: the middle estimate sits 2.5-fold (0.40 log units) below what was measured, and the stated range ends below it.
By their numbers in this assay, from the lowest: compounds 1, 3, 4 and 2 (each within the scatter of the next, the first and the last beyond it).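

In this assay, among the compounds shown here, the change from 3,4-dichlorophenyl to 4-chloro-3-(trifluoromethyl)phenyl gives a 2.2-fold higher number from compound 1 to compound 4 (0.35 log units; beyond the scatter) as the first measured step at this position. The number therefore responds to this swap, in which a chloro group of 1 heavy atom gives way to a trifluoromethyl group of 4, although the step is modest and compound 4 stays in the same sub-micromolar range as compound 1. Nothing available here bears on what lies behind this step.

Going by these compounds, a single swap cannot show which feature of the group matters, so it remains open whether a methyl, a nitrile or an amine at this position would give a lower or a higher number. On these data alone, it is also open whether the same swap would give a step of similar size on compound 2, which has a hydrogen in place of the methyl on the oxygen.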